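Piperazine for methoxy on the pendant phenyl ring

A few compounds are considered here, and "the series" means these few. Any claim that something is new, unique, unknown or untested is made for them only; others in the source may bear on it.

Measured compounds:
compound 1 `Nc1c2c(=O)[nH]c(-c3ccccc3)cc2nn1-c1ccccc1` — 22%
compound 2 `COc1ccc(-c2cc3nn(-c4ccccc4)c(N)c3c(=O)[nH]2)cc1` — 12%

In an assay on isolated protein for inhibition of MAP kinase-activated protein kinase 5 (Homo sapiens), read by mobility shift assay, tested at 30 uM (a higher number here means more inhibition at the concentration tested (going by the name of the read-out), a lower number less inhibition), compound 1 gives 22% and compound 2 gives 12%. The only measured step, a number 10 percentage points lower from compound 1 to compound 2 (within the scatter), is within the scatter, so on the two numbers shown compound 2 sits with compound 1 inside the usual scatter and no order between them can be read.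

Compound 3 `CN1CCN(c2ccc(-c3cc4nn(-c5ccccc5)c(N)c4c(=O)[nH]3)cc2)CC1` differs from compound 2 in one place: 4-methylpiperazin-1-yl in place of methoxy on an aromatic carbon. For the measured compounds named here, the one step that bears on this position, a number 10 percentage points lower from compound 1 to compound 2 (within the scatter), was within the scatter, and nothing measured speaks to a larger group at that carbon. No step beyond the scatter is therefore expected in this assay. Compound 3 is estimated at 15%, range 0% to 35%, which means an expected step of a number 3 percentage points higher from compound 2 to compound 3 (within the scatter).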

Compound 3, a percentage reported as inhibition, at one concentration (the size of the read-out at that concentration, not a potency): 4%
Estimate against measurement, compound 3: 11 percentage points above; low and high end bracket the measured number.
By their numbers in this assay, from the lowest: compounds 3, 2 and 1 (each within the scatter of the next, the first and the last beyond it).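

In this assay the step of a number 8 percentage points lower from compound 2 to compound 3 (within the scatter) does not separate 4-methylpiperazin-1-yl from methoxy on this aromatic carbon, even with the larger group. Set against hydrogen at the same carbon, the group gives a number 18 percentage points lower from compound 1 to compound 3 (beyond the scatter) as the only step at this position beyond the scatter, and a modest one. No measurement here accounts for that step.

From the compounds shown here alone, a primary amine or a carboxylic acid on this carbon remains open. So does whether any group there gives more inhibition than hydrogen does.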